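The source may hold more compounds than are shown below. What is called first, only, known or untested is meant among the compounds shown, and "the series" means these compounds.

Working notes on the series. Of the compounds shown here, three have been measured in an ADME assay on the whole organism (Rattus norvegicus) for pharmacokinetics, read by LC-MS; a lower number here means that more of the compound stays in the plasma, a higher number that more of the compound sits outside the plasma. Compound 1 `Cc1ccc(-c2c3c(nc(C)c2[C@H](OC(C)(C)C)C(=O)O)CCN(c2ccccc2)C3)cc1` gives 3 L/kg. Compound 3 `Cc1nc2c(c(-c3cc(F)c4c(c3C)CCCO4)c1[C@H](OC(C)(C)C)C(=O)O)CN(CCCc1ccccc1)CC2` gives 6 L/kg. Compound 2 `Cc1ccc(-c2c3c(nc(C)c2C(OC(C)(C)C)C(=O)O)CCN(CCCC2CCCC2)C3)cc1` gives 66 L/kg, the highest number of the three, beyond the scatter against both compound 3 and compound 1.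

The next step goes from compound 2 to compound 4 `Cc1ccc(-c2c3c(nc(C)c2C(OC(C)(C)C)C(=O)O)CCN(Cc2ccccc2-c2ccccc2)C3)cc1`, with the difference (2-phenylphenyl in place of 2-cyclopentylethyl on a saturated chain carbon bound to an amine nitrogen in a ring).

Among the measured compounds shown here, no step between measured compounds isolates this change. A downward step in this assay is expected from compound 2 to compound 4, beyond the scatter, because compound 3 gives 6 L/kg and compound 1 gives 3 L/kg with other groups on the same nitrogen. The expected step is a 6.6-fold lower number from compound 2 to compound 4 (0.82 log units; beyond the scatter). Compound 4 is estimated at 10 L/kg, in the range 3 L/kg to 30 L/kg.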

Compound 4, volume of distribution at steady state: 9 L/kg
Compound 4: middle estimate off by 1.1-fold (0.05 log units), on the high side; the range from low to high includes it.
By their numbers in this assay, from the lowest: compounds 1, 3 and 4 (each within the scatter of the next, the first and the last beyond it); then compound 2.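

Among the compounds shown here, at this place, on a saturated chain carbon bound to an amine nitrogen in a ring, 2-phenylphenyl in place of 2-cyclopentylethyl gives a 7.3-fold lower number from compound 2 to compound 4 (0.87 log units; beyond the scatter) in this assay, the first step that isolates a change here. The number therefore moves with this group alone while the rest of the structure stays fixed. No measurement at hand bears on the reason for the step.

Still open, on these data alone, is how a pyridyl ring in place of 2-phenylphenyl, or a chain ending in an amine, would move the number.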